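A few compounds are considered here, and "the series" means these few. Any claim that something is new, unique, unknown or untested is made for them only; others in the source may bear on it.

Of the compounds shown here, three sharing one core have been measured in a physicochemical assay for lipophilicity, at pH 7.4; on this read-out higher numbers stand for higher lipophilicity and lower numbers for lower lipophilicity. Compound 1 `CC(C)CN(c1ccc(C(C)(C)C)cc1)S(=O)(=O)c1ccc2c(c1)C(=O)CC(C1CCOCC1)O2` gives 4.97. Compound 2 `CCc1ccc(N(CC(C)C)S(=O)(=O)c2ccc3c(c2)C(=O)CC(C2CCOCC2)O3)cc1` gives 4.21. Compound 3 `CC(C)CN(c1cccc(F)c1)S(=O)(=O)c1ccc2c(c1)C(=O)CC(C1CCOCC1)O2` gives 3.5, the lowest of the three: compound 2 is its nearest neighbour on the read-out and compound 1 the furthest.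

The steps among them show that the group attached to the sulfonamide nitrogen moves this assay markedly. Exchanging ethyl for tert-butyl on an aromatic carbon gave a number 0.76 log units lower from compound 1 to compound 2 (beyond the scatter). Replacing the whole aryl group gave a number 1.47 log units lower from compound 1 to compound 3 (beyond the scatter) and a number 0.71 log units lower from compound 2 to compound 3 (beyond the scatter).

Compound 4 `CC(C)CN(c1cc2ccccc2s1)S(=O)(=O)c1ccc2c(c1)C(=O)CC(C1CCOCC1)O2` is not yet measured. It differs from compound 3 in one place: 1-benzothiophen-2-yl in place of 3-fluorophenyl on a sulfonamide nitrogen. Within the data shown here, no measured step involves 1-benzothiophen-2-yl, so the earlier steps can only set the scale. Those steps, from compound 1 and compound 2 to compound 3, show that a change of the aryl group on the sulfonamide nitrogen readily shifts this assay beyond the scatter. Compound 4 is therefore expected to rise, by an estimated a number 0.90 log units higher from compound 3 to compound 4 (beyond the scatter), to an estimated 4.4, with a likely range from 3.9 to 4.9, landing between compound 2 and compound 1.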

Compound 4, distribution coefficient: 4.01
Beside the measured number, compound 4's estimate is 0.39 log units above it, and the stated range covers the measured number.
By their numbers in this assay, from the lowest: compound 3; then compounds 4 and 2 (each within the scatter of the next); then compound 1.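

Putting 1-benzothiophen-2-yl on the sulfonamide nitrogen in place of 3-fluorophenyl gave a number 0.51 log units higher from compound 3 to compound 4 (beyond the scatter) in this assay, so the aryl group here need not be a phenyl ring for the number to shift: a five-membered aromatic ring with a hetero atom, joined to a six-membered one, moves it too. In place of 4-ethylphenyl, the same group gave a number 0.20 log units lower from compound 2 to compound 4 (within the scatter), so these two quite different groups cannot be told apart on this read-out, and a change of ring type at this position need not change the number. In place of 4-(tert-butyl)phenyl, it gave a number 0.96 log units lower from compound 1 to compound 4 (beyond the scatter), so among these four compounds, having two aromatic rings on this nitrogen did not match the number of the phenyl ring carrying tert-butyl.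

Going by these compounds, how this assay would respond to an amine or a carboxylic acid on this aryl group, or to a pyridine ring in its place, remains open. The compounds shown also offer no measured evidence that explains any of these shifts.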